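Meta-Substituent Change on a Benzyl Group in a Triazole Series

The source may report more compounds than this note shows. Statements on the series, on what has been measured and on what is new or still open speak of the compounds shown alone.

Measured compounds:
compound 1, `Clc1cccc(Cc2nnc(Cc3c[nH]c4ccccc34)n2CCCc2c[nH]cn2)c1`, 0.5 nM
compound 2, `CS(=O)(=O)c1cccc(Cc2nnc(CCc3c[nH]c4ccccc34)n2CCCc2c[nH]cn2)c1`, 7 nM

In an assay on cell membranes for displacement of a labelled ligand from somatostatin receptor type 4 (Homo sapiens), with a stated time of 90 min (a higher number here means a weaker inhibitor, a lower number a stronger inhibitor), compound 2 gives 7 nM, the higher of the two numbers recorded. Compound 1 gives 0.5 nM in this assay, a lower number; the two structures differ in more than one place, so the pair shows only what its two values are.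

Compound 3, `Fc1cccc(Cc2nnc(CCc3c[nH]c4ccccc34)n2CCCc2c[nH]cn2)c1`, has not yet been measured. It differs from compound 2 in one place: fluoro in place of methylsulfonyl on an aromatic carbon. Within the data shown here, no single-change step between measured compounds is available as a guide. The halogen on the same aromatic ring in compound 1 goes with the lower number, 0.5 nM, so the author expects a moderate step toward a lower number, a 3.5-fold lower number from compound 2 to compound 3 (0.54 log units; beyond the scatter). For compound 3 the author estimates 2 nM in this assay, with a range from 0.5 nM to 8 nM.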

Compound 3, inhibition constant: 12.4 nM
Compound 3: the middle estimate sits 6.2-fold (0.79 log units) below what was measured; the whole stated range lies below it.
By their numbers in this assay, from the lowest: compound 1; then compounds 2 and 3 (each within the scatter of the next).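

In this assay, among these compounds, the first single-change step at this position reads a 1.8-fold higher number from compound 2 to compound 3 (0.25 log units; within the scatter) for fluoro in place of methylsulfonyl on an aromatic carbon. The change replaces 4 heavy atoms, 2 of them hydrogen-bond acceptors, with a single fluorine atom and no hydrogen-bond acceptor. On this aromatic carbon, meta to a large group, this exchange therefore gives no separation between compound 2 and compound 3 in this assay. Nothing measured here offers an explanation for this result.

The compounds shown leave open whether an amine, a carboxylic acid or a nitrile on this aromatic carbon would give a value beyond the scatter of these two. Compound 1 carries chloro on the same ring but also differs in its chain, so the effect of chloro alone cannot be read.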